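A Methyl Added to the Chain of Compound 1

The compounds below may be only part of what the source reports. "The series", "measured", "known", "first", "only" and "open" are said of these compounds alone.

Compound 1 `O=C1c2ccccc2C(=O)N1CCOC(=S)N(C(=O)c1cccc([N+](=O)[O-])c1)c1ccc(Cl)cc1`: 18000 nM
Compound 2 `O=C1c2ccccc2C(=O)N1CCOC(=S)N(C(=O)c1cccc(Cl)c1Cl)c1ccc(Cl)cc1`: 54000 nM
Compound 3 `O=C1c2ccccc2C(=O)N1CCOC(=S)N(C(=O)c1cc([N+](=O)[O-])ccc1Cl)c1ccc(Cl)cc1`: 45000 nM

In an ADME assay on MT4 cells (Homo sapiens) for cytotoxicity, read by MTT assay (on this read-out higher numbers stand for lower toxicity in this test and lower numbers for higher toxicity in this test), compound 1 has the lowest of these three numbers. Compound 4 `CC(CN1C(=O)c2ccccc2C1=O)OC(=S)N(C(=O)c1cccc([N+](=O)[O-])c1)c1ccc(Cl)cc1` differs from it by one change, methyl in place of hydrogen on a saturated chain carbon bound to an oxygen on an unsaturated carbon and a saturated chain carbon. Going by the values given here, no measured step touches this chain. The steps of a 3.0-fold higher number from compound 1 to compound 2 (0.48 log units; beyond the scatter), a 2.5-fold higher number from compound 1 to compound 3 (0.40 log units; beyond the scatter) and a 1.2-fold lower number from compound 2 to compound 3 (0.08 log units; within the scatter) all change the aromatic group on the carbonyl, so they show only how far nearby edits have moved the number. The expected step is small and within the scatter, a 1.2-fold higher number from compound 1 to compound 4 (0.09 log units; within the scatter). For compound 4 the estimated value is 22000 nM, with an expected range from 9000 nM to 55000 nM.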

Compound 4, half-maximal cytotoxic concentration: 31000 nM
The estimate for compound 4 lay 1.4-fold (0.15 log units) below the measured number, and the stated range covers the measured number.
By their numbers in this assay, from the lowest: compounds 1, 4, 3 and 2 (each within the scatter of the next, the first and the last beyond it).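

Going by these compounds alone, this is the first change to the chain rather than to the aromatic group on the carbonyl. In this assay, methyl in place of hydrogen gives a 1.7-fold higher number from compound 1 to compound 4 (0.24 log units; within the scatter) and so leaves compound 4 within the scatter of compound 1, showing that this saturated chain carbon accepts one methyl without a clear shift in the number. Nothing measured here explains this result.

As far as these compounds go, whether a longer chain or a hydroxyl group on this carbon would stay as close remains open. So does whether methyl here would do the same alongside the aromatic groups of compound 2 and compound 3.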